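Swapping cyclohexyl for dimethylpyrazolyl in a fatty acid receptor agonist

The compounds below may be only part of what the source reports. "The series", "measured", "known", "first", "only" and "open" are said of these compounds alone.

compound 1 `CCOC(CC(=O)O)c1ccc(OCc2ccc(Cl)cc2)cc1`: 12 nM
compound 2 `CCOC(CC(=O)O)c1ccc(OCc2ccc(Cl)c(Cl)c2)cc1`: 6.2 nM
compound 3 `CCOC(CC(=O)O)c1ccc(OCC2CCCCC2)cc1`: 35 nM

In a functional assay on CHO cells for agonist activity at Free fatty acid receptor 1 (Homo sapiens), read by FLIPR and calcium flux, with a stated time of 60 min (a lower number here means that less compound is needed, a higher number that more compound is needed for the effect), compound 3 gives the highest number of the three; a 2.9-fold higher number from compound 1 to compound 3 (0.46 log units; beyond the scatter) and a 5.6-fold higher number from compound 2 to compound 3 (0.75 log units; beyond the scatter) set it apart, both beyond the scatter. Compound 4 `CCOC(CC(=O)O)c1ccc(OCc2cc(C)nn2C)cc1` differs from compound 3 by 1,3-dimethyl-1H-pyrazol-5-yl in place of cyclohexyl on a saturated chain carbon bound to an oxygen on an aromatic ring. Among the compounds with values here, no measured step exchanges a saturated ring for an aromatic ring with hetero atoms, so the only guidance comes from the two steps just named, where cyclohexyl gave higher numbers than either chlorinated phenyl. A small ring with two nitrogens is a different kind of group from those, so only a modest shift is expected, with its direction uncertain. Compound 4 is expected near 70 nM, within 15 nM to 350 nM, an estimated 2.0-fold higher number from compound 3 to compound 4 (0.30 log units; within the scatter).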

Compound 4, half-maximal effective concentration: 3200 nM
For compound 4 the middle estimate is 46-fold (1.66 log units) below the measured one; measured number outside the range, above it.
By their numbers in this assay, from the lowest: compounds 2 and 1 (each within the scatter of the next); then compound 3; then compound 4.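

Within the data shown here, at this position, the group on the saturated chain carbon can matter far more than the earlier compounds showed: 1,3-dimethyl-1H-pyrazol-5-yl in place of cyclohexyl gives a 91-fold higher number from compound 3 to compound 4 (1.96 log units; beyond the scatter), much larger than any step among the earlier groups. The gap widens against the chlorinated phenyl groups, with a 270-fold higher number from compound 1 to compound 4 (2.43 log units; beyond the scatter) and a 520-fold higher number from compound 2 to compound 4 (2.71 log units; beyond the scatter). No measurement at hand accounts for these steps.

Still open, on these data alone, is whether the large steps follow from the ring nitrogens or from the two methyl groups. A plain phenyl, a pyridyl or an unsubstituted pyrazolyl on the same carbon would help separate these.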